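This account rests on a few compounds, and the source may have more. Where it says the series, first, only, none or still open, it means among the compounds named here.

Measured so far in this series:

compound 1, `O=C(/C=C/c1ccc(OCCO)c(OCCO)c1)NCCn1c(C(F)(F)F)cc2ccccc21`: 260 nM
compound 2, `COc1ccc(/C=C/C(=O)NCCn2c(C(F)(F)F)cc3ccccc32)cc1`: 305 nM
compound 3, `COc1ccc(/C=C/C(=O)NCCn2c(C)cc3ccccc32)cc1`: 16.5 nM

All three numbers come from an assay on C6 cells for antagonist activity at prostaglandin E2 receptor EP2 subtype (Homo sapiens), read by TR-FRET, with stated times of 10 min and 40 min, tested at 1 uM; on this read-out higher numbers stand for weaker inhibition and lower numbers for stronger inhibition. In this assay compound 1 gives 260 nM, compound 2 gives 305 nM and compound 3 gives 16.5 nM. Compound 1 and compound 2 sit within the usual scatter of each other, and the difference between their two cores is not broken down here.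

One change is measured directly. From compound 2 to compound 3 the change is methyl in place of trifluoromethyl on an aromatic carbon and the step is an 18-fold lower number from compound 2 to compound 3 (1.27 log units; beyond the scatter).

Compound 4, `Cc1cc2ccccc2n1CCNC(=O)/C=C/c1ccc(OCCO)c(OCCO)c1`, has not yet been measured. It differs from compound 1 by methyl in place of trifluoromethyl on an aromatic carbon. The place of the change is described in the same words for both pairs, so this is the same change, now made on the core of compound 1 rather than that of compound 2.

Because compound 1 gives 260 nM and the same change gave an 18-fold lower number from compound 2 to compound 3 (1.27 log units; beyond the scatter), a step of similar size is expected for compound 4. For compound 4 the expected step in this assay is a 17-fold lower number from compound 1 to compound 4 (1.24 log units; beyond the scatter). Compound 4 is therefore estimated at 15 nM, with a range from 5 nM to 50 nM. Among the compounds with values here, only one earlier instance of the change is available, so the range is kept wide.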

Compound 4, antagonist equilibrium constant: 11.4 nM
The estimate for compound 4 lay 1.3-fold (0.12 log units) above the measured number; low and high end bracket the measured number.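

In this assay, methyl in place of trifluoromethyl on an aromatic carbon of the five-membered ring gives a 23-fold lower number from compound 1 to compound 4 (1.36 log units; beyond the scatter), so the large step seen on the core of compound 2 appears again on the core of compound 1. Set side by side, the two steps show no difference beyond the scatter, and on these two cores the change carries over with its size intact: the same change on two cores in this assay, an 18-fold lower number (1.27 log units; beyond the scatter) from compound 2 to compound 3 and a 23-fold lower number (1.36 log units; beyond the scatter) from compound 1 to compound 4, 1.2-fold (0.09 log units) apart, within the scatter of two such steps. This is a finding from two matched pairs in one assay: it supports carrying the change between these two cores but does not establish a rule for other cores, and the numbers give no reason why the step occurs.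

On these data alone, only methyl and trifluoromethyl are compared at this place, so it remains open whether the step would be kept with another group there, such as ethyl, a chlorine atom or a nitrile. As far as these compounds go, it also remains open how the step would hold up on a core carrying an amine or a carboxylic acid in the part where the core of compound 1 and the core of compound 2 differ.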